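Lengthening the two-position substituent from propylsulfanyl to butylamino

The compounds below may be only part of what the source reports. "The series", "measured", "known", "first", "only" and "open" are said of these compounds alone.

The measured compounds:
compound 1 `CNc1nc(N)c2nc(O)n(Cc3ccccc3)c2n1` with 1 uM
compound 2 `Cc1nc(N)c2nc(O)n(Cc3ccccc3)c2n1` with 1 uM
compound 3 `CCCSc1nc(N)c2nc(O)n(Cc3ccccc3)c2n1` with 0.01 uM

All three were tested in a functional assay (spleen, spleen) for activation, with Mus musculus as the target; a lower number here means that less compound is needed, a higher number that more compound is needed for the effect. Compound 3 has the lowest number of the three; its nearest neighbour is compound 1, separated by a 100-fold lower number from compound 1 to compound 3 (2.00 log units; beyond the scatter), and compound 2 stands equally far off, by a 100-fold lower number from compound 2 to compound 3 (2.00 log units; beyond the scatter). Compound 1 and compound 2 are not separated beyond the scatter: no change at the digits printed from compound 1 to compound 2 (within the scatter).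

Compound 4 `CCCCNc1nc(N)c2nc(O)n(Cc3ccccc3)c2n1` has not yet been measured. It differs from compound 3 by butylamino in place of propylsulfanyl on an aromatic carbon. Among the compounds with values here, the steps that bear on this change are the two large ones into compound 3, a 100-fold lower number from compound 1 to compound 3 (2.00 log units; beyond the scatter) and a 100-fold lower number from compound 2 to compound 3 (2.00 log units; beyond the scatter), which show that the group at this position can move the number greatly; the step of no change at the digits printed from compound 1 to compound 2 (within the scatter) shows that not every exchange there does so. Butylamino shares its nitrogen with the methylamino of compound 1 and its chain length roughly with the propylsulfanyl of compound 3, so compound 4 is expected to land between those, closer to compound 3; the estimated step is a 3.0-fold higher number from compound 3 to compound 4 (0.48 log units; beyond the scatter). For compound 4 the expected value is 0.03 uM, with a range from 0.003 uM to 0.3 uM.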

Compound 4, minimum effective concentration: 1 uM
For compound 4 the middle estimate is 33-fold (1.52 log units) below the measured one; the measured number lies above the stated range.
By their numbers in this assay, from the lowest: compound 3; then compounds 1, 2 and 4 (each within the scatter of the next).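

In this assay, the large step (a 100-fold higher number from compound 3 to compound 4 (2.00 log units; beyond the scatter)) shows that this position does not tolerate every chain of similar length equally: butylamino does not keep what propylsulfanyl gives. Extending the chain on the nitrogen changes nothing that can be seen (no change at the digits printed from compound 1 to compound 4 (within the scatter)), and the step from the methyl group is equally flat (no change at the digits printed from compound 2 to compound 4 (within the scatter)). Among these four compounds, only the propylsulfanyl group of compound 3 stands apart, and chain length on the nitrogen alone does not reproduce its effect.

No measurement shown here explains the gap between the sulfur-linked and nitrogen-linked chains. On these data alone, whether the sulfur itself or the particular chain matters remains open, and butylsulfanyl, ethylsulfanyl or propoxy at this position would help to separate the two.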